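The source may report more compounds than this note shows. Statements on the series, on what has been measured and on what is new or still open speak of the compounds shown alone.

Compound 1 `Cc1c(S(=O)(=O)N/C(=N\O)Nc2ccc(Cl)cc2)sc2ccc(Cl)cc12` was tested in a functional assay on MOLT-4 cells (Homo sapiens) for cytotoxicity (on this read-out lower numbers stand for stronger inhibition and higher numbers for weaker inhibition), and compound 1 gives 38 ug/mL. Two further measured compounds share part of this pattern: compound 2 `O=[N+]([O-])c1ccc(Oc2c(Cl)cc(S(=O)(=O)N/C(=N\O)Nc3ccc(Cl)cc3)cc2Cl)cc1` gives 55 ug/mL, and compound 3 `O=[N+]([O-])c1ccc(Oc2c(Cl)cc(S(=O)(=O)N/C(=N\O)Nc3ccc(Cl)cc3)cc2Cl)c(Cl)c1` gives 56 ug/mL. How the core of compound 1 differs from the core of compound 2 is not broken down here. Between compound 2 and compound 3 the only change is chloro in place of hydrogen on an aromatic carbon, and that step reads a 1.0-fold higher number from compound 2 to compound 3 (0.01 log units; within the scatter).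

Compound 4 `Cc1c(S(=O)(=O)N/C(=N\O)Nc2ccc(Cl)c(Cl)c2)sc2ccc(Cl)cc12` has not yet been measured. It differs from compound 1 by chloro in place of hydrogen on an aromatic carbon. Among the compounds with values here, this is the same kind of change as the one from compound 2 to compound 3, though not the same: in compound 3 the entering chloro sits ortho to a large group and meta to a nitro group, whereas in compound 4 it sits ortho to a chloro group and meta to a large group. The step from compound 1 to compound 4 is expected to be a 1.1-fold lower number from compound 1 to compound 4 (0.02 log units; within the scatter), resting on the near-flat step seen in a 1.0-fold higher number from compound 2 to compound 3 (0.01 log units; within the scatter). On that basis compound 4 is estimated at 36 ug/mL, with the expected range running from 15 ug/mL to 85 ug/mL.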

Compound 4, half-maximal inhibitory concentration: > 300 ug/mL
Compound 4: no number, only a limit; the forecaster's own chance of this, stated with the estimate: 5%; at least 8.3-fold (0.92 log units) between middle value and limit.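

In this assay, changing 4-chlorophenyl to 3,4-dichlorophenyl gives an at least 7.8-fold higher number from compound 1 to compound 4 (0.89 log units; beyond the scatter). From the compounds shown here alone, compound 4 reads > 300 ug/mL, which is a limit of the assay and not a number, so the full size of this step remains unknown. This chloro change therefore does not carry over unchanged from one core to the other, although two pairs cannot show why or which step is more typical of the series, and the two steps clearly differ: the same change on two cores in this assay, a 1.0-fold higher number (0.01 log units; within the scatter) from compound 2 to compound 3 and an at least 7.8-fold higher number (0.89 log units; beyond the scatter) from compound 1 to compound 4, at least 7.7-fold (0.88 log units) apart, beyond the scatter of two such steps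

The compounds shown leave open whether a smaller fluoro group or a methoxy group in place of this chloro would also weaken inhibition on the core of compound 1. They also leave open how a methyl group there would behave.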